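Adding a Second Methoxy to an Enaminone Cytotoxicity Series

The source may report more compounds than this note shows. Statements on the series, on what has been measured and on what is new or still open speak of the compounds shown alone.

Measured so far:
compound 1, `O=C(/C=C\Nc1ccc(F)cc1)c1nc(-c2ccc(F)cc2)n2ccccc12`: 13200 nM
compound 2, `COc1ccc(N/C=C\C(=O)c2nc(-c3ccc(C(F)(F)F)cc3)n3ccccc23)cc1OC`: > 30000 nM
compound 3, `COc1ccc(N/C=C\C(=O)c2nc(-c3ccc(F)cc3)n3ccccc23)cc1`: 19200 nM

Of the compounds shown here, three share one core and have been tested in a functional assay on A549 cells (Homo sapiens) for cytotoxicity, read by MTT assay, with a stated time of 48 h; a lower number here means a stronger inhibitor, a higher number a weaker inhibitor. Compound 1 gives 13200 nM. Compound 3 gives 19200 nM, and the step of a 1.5-fold higher number from compound 1 to compound 3 (0.16 log units; within the scatter) is within the scatter, so compound 1 and compound 3 cannot be told apart on these numbers. For compound 2 the value of > 30000 nM is a limit of the assay and not a number (the limit of > 30000 nM in this assay, at which 1 of the 3 values shown sits).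

Compound 4, `COc1ccc(N/C=C\C(=O)c2nc(-c3ccc(F)cc3)n3ccccc23)cc1OC`, is not yet measured. Compared with compound 3 the change is methoxy in place of hydrogen on an aromatic carbon. Going by the values given here, only one measured step exists, and it concerns a different position, so it says nothing direct about this change. Among the compounds with values here, compound 2 carries the same 3,4-dimethoxyphenyl group and reaches only a limit, but it also differs in the trifluoromethyl group, so no step can be drawn from it.

The expectation for compound 4 is therefore a step of a 1.3-fold higher number from compound 3 to compound 4 (0.11 log units; within the scatter) that may not exceed the scatter, leaning toward a weaker value, giving an estimated 25000 nM with a range of 11000 nM to 60000 nM.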

Compound 4, half-maximal inhibitory concentration: > 30000 nM
Compound 4: a limit, no number; the forecaster's own chance of this, stated with the estimate: 40%; at least 1.2-fold (0.07 log units) between middle value and limit.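

In this assay compound 4 gives > 30000 nM, which is a limit of the assay and not a number, so the true size of the change stays unknown: the limit of > 30000 nM in this assay, at which 2 of the 4 values shown sit.

Going from 4-methoxyphenyl to 3,4-dimethoxyphenyl gives an at least 1.5-fold higher number from compound 3 to compound 4 (0.19 log units; that floor lies within the scatter), so this added methoxy is not shown on its own to weaken the compound. Putting 3,4-dimethoxyphenyl in place of 4-fluorophenyl on the amine nitrogen gives an at least 2.2-fold higher number from compound 1 to compound 4 (0.35 log units; beyond the scatter), the only readable step shown that clears the scatter, while the step between compound 2 and compound 4 cannot be read.

The compounds shown leave open whether another group at this place on the ring, such as a hydroxy group, an amine or a chlorine, would give a measurable number. They also leave open what number compound 4 would give if the assay reached higher concentrations.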